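A few compounds are considered here, and "the series" means these few. Any claim that something is new, unique, unknown or untested is made for them only; others in the source may bear on it.

Compound 1 `CCOC(=O)c1nc(C)c2c(c1N)C(=O)N(Cc1ccccc1)C2=O` and compound 2 `COC(=O)c1nc(C)c2c(c1N)C(=O)N(Cc1ccccc1)C2=O` share one core, and compound 3 `Cc1noc(-c2nc(C)c3c(c2N)C(=O)N(Cc2ccccc2)C3=O)n1` keeps that core too. In an ADME assay on Vero cells (Chlorocebus sabaeus) for cytotoxicity, read by MTT assay (on this read-out lower numbers stand for stronger inhibition and higher numbers for weaker inhibition), compound 1 reaches only a limit of the assay, > 100000 nM, so no number is known for it. For compound 2 this assay gives no result at all: "not determined" (no result reported). Where compound 2 stands on the numbers shown is thus open; the single value in hand sits at a limit, (the limit of > 100000 nM in this assay, at which 1 of the 2 values shown sits), which says that cytotoxicity was too weak to be measured there.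

Compound 3 differs from compound 2 in one place (3-methyl-1,2,4-oxadiazol-5-yl in place of methoxycarbonyl on an aromatic carbon). Among the measured compounds shown here, no pair of measured compounds shows a step in this assay, so no measured change can be used to size the move from compound 2 to compound 3. With only a limit for compound 1 as a guide, the step is expected to be none beyond the scatter in this assay, and a further limit is the likeliest outcome. Compound 3 is expected to sit around 100000 nM, between 30000 nM and 300000 nM.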

Compound 3, half-maximal inhibitory concentration: > 100000 nM
Compound 3: only a limit was reported; the forecaster's own chance of this, stated with the estimate: 75%; the middle value sits exactly at the limit.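

Compound 1 and compound 3 each reach only a limit in this assay, so no step between them can be read, neither its size nor its direction: the limit of > 100000 nM in this assay, at which 2 of the 3 values shown sit.

The compounds shown leave open how cytotoxic compound 1 and compound 3 really are, and whether 3-methyl-1,2,4-oxadiazol-5-yl in place of ethoxycarbonyl changes that at all.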